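This account rests on a few compounds, and the source may have more. Where it says the series, first, only, none or still open, it means among the compounds named here.

For the measured compounds named here, in a physicochemical assay, with a stated time of 6 min (a higher number here means a weaker inhibitor, a lower number a stronger inhibitor), compound 1 `COc1ccc(NC(=O)Nc2nc(-c3cc4cc([N+](=O)[O-])ccc4o3)cs2)cc1` gives 121000 nM, the higher of the two numbers measured so far, which makes it the weaker inhibitor of the pair. Going by the values given here, compound 2 `COc1ccc(NC(=O)Nc2nc(-c3cc4ccccc4o3)cs2)cc1`, the only other measured compound, gives 17400 nM. Compound 3 `O=C(Nc1ccccc1)Nc1nc(-c2cc3cc([N+](=O)[O-])ccc3o2)cs1` has not yet been measured. It keeps the nitro group of compound 1 but carries hydrogen in place of methoxy on an aromatic carbon.

Among the compounds with values here, the only measured step, a 7.0-fold lower number from compound 1 to compound 2 (0.84 log units; beyond the scatter), is a modest one, with hydrogen in place of nitro on an aromatic carbon. Within the data shown here, the methoxy group stays untouched in that step, so no measured pair shows what its loss does to the number. That step shows only the size that a single replacement by hydrogen reached in this small set. With no direct evidence for a direction, no change beyond the scatter is expected, although a move of similar size remains possible. The expected change is a 1.2-fold lower number from compound 1 to compound 3 (0.08 log units; within the scatter). For compound 3 the estimate is 100000 nM, with an expected range of 35000 nM to 300000 nM.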

Compound 3, half-maximal inhibitory concentration: 183000 nM
For compound 3 the middle estimate is 1.8-fold (0.26 log units) below the measured one, and the stated range covers the measured number.
By their numbers in this assay, from the lowest: compound 2; then compounds 1 and 3 (each within the scatter of the next).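

In this assay, the change from 4-methoxyphenyl to phenyl gives a 1.5-fold higher number from compound 1 to compound 3 (0.18 log units; within the scatter), so with the nitro group in place, hydrogen at this position on the six-membered aromatic ring cannot be told apart from methoxy. For the compounds shown here, this is the first measured replacement at this end of the molecule, and it shows that losing the methoxy group there does not move the number beyond the scatter. It also stands apart from the only other measured step, a 7.0-fold lower number from compound 1 to compound 2 (0.84 log units; beyond the scatter), which replaces the nitro group with hydrogen and does lie beyond the scatter, so among these compounds only the replacement of nitro moves the number by more than the scatter.

The compounds shown leave open whether the same holds for hydrogen in place of methoxy when the nitro group is absent, and what a hydroxyl group, a chlorine atom, an amine or a longer chain such as ethoxy would do at this position. Nothing available explains why the methoxy group can be lost here with so little effect on the number.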